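Stretching the ethoxy group of compound 2 to isobutoxy

This account rests on a few compounds, and the source may have more. Where it says the series, first, only, none or still open, it means among the compounds named here.

In a functional assay on the whole organism with Rattus norvegicus as the target (on this read-out higher numbers stand for an effect only at larger amounts of compound and lower numbers for an effect already at smaller amounts), compound 2 `CCOc1ccccc1-c1ncc(-c2nn[nH]n2)c(O)n1` gives 0.09 mg/kg, the second highest of three numbers. Where compound 2 has ethoxy, compound 1 `Oc1nc(-c2ccccc2)ncc1-c1nn[nH]n1` has hydrogen and gives 100 mg/kg. Compound 3 `CC(C)Oc1ccccc1-c1ncc(-c2nn[nH]n2)c(O)n1`, which carries isopropoxy instead, gives 0.04 mg/kg.

The next compound is compound 4 `CC(C)COc1ccccc1-c1ncc(-c2nn[nH]n2)c(O)n1`, and the change is isopropyl in place of methyl on a saturated chain carbon bound to an oxygen on an aromatic ring: ethoxy becomes isobutoxy. Adding ethoxy to the hydrogen compound produced a large drop, a 1100-fold lower number from compound 1 to compound 2 (3.05 log units; beyond the scatter), and adding isopropoxy produced a 2500-fold lower number from compound 1 to compound 3 (3.40 log units; beyond the scatter). Those steps show how much having such a group matters, but they say little about altering one already in place. The closer guide is a 2.3-fold lower number from compound 2 to compound 3 (0.35 log units; beyond the scatter), a modest step that also enlarges the chain. Going by the values given here, no measured compound carries isobutoxy, so the direction remains uncertain and a step beyond the scatter is not expected in this assay. The estimated change is a 1.3-fold lower number from compound 2 to compound 4 (0.11 log units; within the scatter). Compound 4 is expected at 0.07 mg/kg, within an estimated range of 0.02 mg/kg to 0.3 mg/kg.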

Compound 4, dose for 50% inhibition: 0.1 mg/kg
Compound 4: the middle estimate sits 1.4-fold (0.15 log units) below what was measured, within the range that was stated.
By their numbers in this assay, from the lowest: compound 3; then compounds 2 and 4 (each within the scatter of the next); then compound 1.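

In this assay, the larger isobutoxy group gives a 1.1-fold higher number from compound 2 to compound 4 (0.05 log units; within the scatter), so this change in chain size leaves the number within the scatter, while replacing hydrogen with isobutoxy still gives a 1000-fold lower number from compound 1 to compound 4 (3.00 log units; beyond the scatter). The branch point matters more than the earlier steps could show: a 2.5-fold higher number from compound 3 to compound 4 (0.40 log units; beyond the scatter), so the modest advantage of compound 3 does not carry over to a larger group, and among these three groups the number does not simply fall as the chain grows. No available evidence explains why isopropoxy differs from isobutoxy here.

The compounds shown leave open how a shorter methoxy group or a longer straight butoxy chain would behave in this place. They also leave open whether an amine at the end of such a chain would be tolerated.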